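A few compounds are considered here, and "the series" means these few. Any claim that something is new, unique, unknown or untested is made for them only; others in the source may bear on it.

Measured in a functional assay on PC-3 cells (Homo sapiens) for antiproliferative activity, read by sulforhodamine B assay, with a stated time of 48 h; a higher number here means a weaker inhibitor of growth, a lower number a stronger inhibitor of growth:
- compound 1 `CCCCCCCCCCCCCCCCCC(=O)N1CCOCC1`: 41.1 ug/mL
- compound 2 `CCCCCCCC/C=C\CCCCCCCC(=O)N1CCCC1`: 13 ug/mL
- compound 3 `CCCCC/C=C\C/C=C\CCCCCCCC(=O)N1CCCCC1`: 53.6 ug/mL

Compound 1, at 41.1 ug/mL, cannot be told apart from compound 3, as their two numbers lie within the scatter of each other. Compound 2 gives a lower number, beyond the scatter, and so shows stronger growth inhibition than compound 1.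

The unmeasured compound 4 `CCCCCCCCCCCCCCCC(=O)N1CCOCC1` keeps the core of compound 1. The change is hydrogen in place of ethyl on a saturated chain carbon, ten or more bonds along the chain from a carbonyl carbon.

Among the measured compounds shown here, compound 1, compound 2 and compound 3 each differ from one another in more than one place, so no measured pair shows this change alone. With no such evidence, no step beyond the scatter is expected in this assay, in either direction. The expected move, a 1.2-fold lower number from compound 1 to compound 4 (0.07 log units; within the scatter), is therefore small and uncertain. Compound 4 is estimated at 35 ug/mL, with an expected range of 14 ug/mL to 80 ug/mL.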

Compound 4, concentration for 50% growth inhibition: 22.2 ug/mL
Estimate against measurement, compound 4: 1.6-fold (0.20 log units) above; low and high end bracket the measured number.
By their numbers in this assay, from the lowest: compounds 2, 4, 1 and 3 (each within the scatter of the next, the first and the last beyond it).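

In this assay, among the compounds shown here, a 1.9-fold lower number from compound 1 to compound 4 (0.27 log units; within the scatter) gives the first direct reading of hydrogen in place of ethyl on a saturated chain carbon, ten or more bonds along the chain from a carbonyl carbon. The step lies within the scatter, so with the core of compound 1 kept, this change cannot be told apart from the variation between repeated measurements. No measurement at hand explains the size of this step.

The compounds shown leave open whether a longer chain, or a carboxylic acid in place of the ethyl, would give a step beyond the scatter at this place. They also leave open whether the same change would read alike on the unsaturated chains of compound 2 and compound 3, which carry other cores.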